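Cytotoxicity notes on the step from compound 2 to compound 4

This account rests on a few compounds, and the source may have more. Where it says the series, first, only, none or still open, it means among the compounds named here.

Among the compounds with values here, compound 2 `O=C(Nc1cc(F)c(F)c(F)c1)N1Cc2c(-c3ccc(F)cc3F)cnn2CC1C1CC1` gives 32100 nM in a toxicity assay on HepG2 2.2.15 cells (Homo sapiens) for cytotoxicity, read by CellTiter-Glo (on this read-out lower numbers stand for higher toxicity in this test and higher numbers for lower toxicity in this test), the lowest of the two numbers measured so far. Compound 1 `CC1CN(C(=O)Nc2cc(F)c(F)c(F)c2)Cc2c(N3CC(C#N)CC3=O)cnn21` gives 115000 nM in this assay, a gap beyond the usual scatter. Compound 3 `O=C1CC(c2ccccc2)CN1c1cnn2c1CN(C(=O)Nc1cc(F)c(F)c(F)c1)C(Cc1ccccc1)C2` gives only a limit of the assay, > 2000 nM; (the limit of > 2000 nM in this assay, at which 1 of the 3 values shown sits). Compound 4 `O=C1CC(c2ncccn2)CN1c1cnn2c1CN(C(=O)Nc1cc(F)c(F)c(F)c1)C(C1CC1)C2` is not yet measured and differs from compound 2 in one place: 2-oxo-4-(pyrimidin-2-yl)pyrrolidin-1-yl in place of 2,4-difluorophenyl on an aromatic carbon. Within the data shown here, no measured pair isolates this change, so its size can only be expected. Given that compound 1 gives 115000 nM, compound 4 is expected to shift by a 2.5-fold higher number from compound 2 to compound 4 (0.40 log units; beyond the scatter), toward lower toxicity. Compound 4 is estimated at 80000 nM, with a range from 25000 nM to 200000 nM.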

Compound 4, half-maximal cytotoxic concentration: > 200000 nM
Compound 4 was reported as a limit; the forecaster's own chance of this, stated with the estimate: 30%; middle value at least 2.5-fold (0.39 log units) from the limit.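

In this assay, within the data shown here, 2-oxo-4-(pyrimidin-2-yl)pyrrolidin-1-yl in place of 2,4-difluorophenyl on this aromatic carbon gives an at least 6.2-fold higher number from compound 2 to compound 4 (0.79 log units; beyond the scatter), a step toward lower toxicity in this test that no earlier pair isolated. Compound 4 stands only as a limit, so the full size of the step stays unknown: the limit of > 200000 nM in this assay, at which 1 of the 4 values shown sits.

The step does not separate the five-membered non-aromatic ring from the pyrimidine ring it carries. Also open, as far as these compounds go, is how an amine or a carboxylic acid on this aromatic carbon would read in this assay.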